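A few compounds are considered here, and "the series" means these few. Any claim that something is new, unique, unknown or untested is made for them only; others in the source may bear on it.

Compound 2, with the structure `COc1ccc(C(=O)C2Sc3nnc(-c4cc(OC)c(OC)c(OC)c4)n3NC2c2cccs2)cc1`, is one of two compounds examined in a functional assay on MCF7 cells (Homo sapiens) for cytotoxicity, read by MTT assay, with a stated time of 48 h (a higher number here means a weaker inhibitor, a lower number a stronger inhibitor), where compound 2 gives 49500 nM. The other, compound 1, with the structure `COc1cc(-c2nnc3n2NC(c2ccco2)C(C(=O)c2ccccc2C)S3)cc(OC)c1OC`, gives 69900 nM in this assay. Compound 2 has the lower of the two numbers, yet the gap between them is within the usual scatter, so the two values cannot be told apart with confidence. Compound 3, with the structure `COc1ccc(C(=O)C2Sc3nnc(-c4cc(OC)c(OC)c(OC)c4)n3NC2c2ccco2)cc1`, carries one change relative to compound 2: furan-2-yl in place of thiophen-2-yl on a saturated ring carbon. Within the data shown here, no pair of measured compounds isolates this exchange, since compound 1 and compound 2 differ elsewhere as well. The step from compound 2 to compound 3 is therefore expected to stay within the scatter, as a 1.1-fold higher number from compound 2 to compound 3 (0.05 log units; within the scatter). Compound 3 is estimated at 55000 nM, with a range from 20000 nM to 150000 nM.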

Compound 3, half-maximal inhibitory concentration: > 100000 nM
Compound 3: no number, only a limit (the forecaster's own chance of this, stated with the estimate: 10%); middle value at least 1.8-fold (0.25 log units) from the limit.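

In this assay compound 3 has only a limit of the assay, not a number: the limit of > 100000 nM in this assay, at which 1 of the 3 values shown sits. Among these compounds, this gives the first direct reading of furan-2-yl in place of thiophen-2-yl on a saturated ring carbon, with the rest of the molecule unchanged: the exchange gives an at least 2.0-fold higher number from compound 2 to compound 3 (0.30 log units; that floor lies within the scatter), so it cannot be called a real loss, although the true gap could be larger. The other single change, 4-methoxyphenyl in place of 2-methylphenyl on a carbonyl carbon with furan-2-yl kept, gives an at least 1.4-fold higher number from compound 1 to compound 3 (0.15 log units; that floor lies within the scatter), and this too does not separate the two groups.

From the compounds shown here alone, the true size of both steps remains open, as compound 3 has no number. Also open, going by these compounds, is how a phenyl ring or an aminomethyl group on the same saturated ring carbon would read.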